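A few compounds are considered here, and "the series" means these few. Any claim that something is new, unique, unknown or untested is made for them only; others in the source may bear on it.

In an ADME assay on microsomes from liver (Mus musculus) for metabolic stability, read by LC-MS, with a stated time of 10 min, tested at 0.5 uM (on this read-out lower numbers stand for a less stable compound and higher numbers for a more stable compound), three compounds have been read so far. Compound 1 `c1ccc2c(c1)CN[C@H](CN(CCCN1CCNCC1)[C@H]1CCCc3cccnc31)C2` gives 88% and compound 2 `c1ccc2c(c1)CN[C@@H](CN(CCCN1CCNCC1)[C@H]1CCCc3cccnc31)C2` gives 92%. Between them lies a number 4 percentage points higher from compound 1 to compound 2 (within the scatter), and what separates them is the fact that compounds 1 and 2 differ only in the configuration as drawn. Compound 3 `c1cnc2c(c1)CCC[C@@H]2N(CCCN1CCNCC1)Cc1nc2ccccc2[nH]1` stands lowest of the three in this assay, at 68%. The steps that reach it are a number 20 percentage points lower from compound 1 to compound 3 (beyond the scatter) and a number 24 percentage points lower from compound 2 to compound 3 (beyond the scatter), both with 1H-benzimidazol-2-yl in place of 1,2,3,4-tetrahydroisoquinolin-3-yl on a saturated chain carbon bound to an amine nitrogen.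

Compound 4 `c1cnc(CN(CCCN2CCNCC2)[C@H]2CCCc3cccnc32)nc1` changes that same place again: pyrimidin-2-yl in place of 1H-benzimidazol-2-yl on a saturated chain carbon bound to an amine nitrogen. In words, pyrimidin-2-yl comes in place of 1H-benzimidazol-2-yl. Among the compounds with values here, no measured compound carries pyrimidin-2-yl, so only those two steps bear on the change, and they show that a new group here can move the number by a modest amount. The configurational step offers no guide to it. With compound 3 at the low end at 68%, a modest rise seems more likely than a further fall, though the direction remains a judgement. The expected step is a number 8 percentage points higher from compound 3 to compound 4 (within the scatter). For compound 4 the estimated value is 76%, with an expected range of 58% to 92%.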

Compound 4, percent of the compound remaining: 78%
Estimate against measurement, compound 4: 2 percentage points below, within the range that was stated.
By their numbers in this assay, from the lowest: compounds 3, 4, 1 and 2 (each within the scatter of the next, the first and the last beyond it).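

Putting pyrimidin-2-yl in place of 1H-benzimidazol-2-yl at this position gives a number 10 percentage points higher from compound 3 to compound 4 (within the scatter), so giving up the fused benzene ring and the hydrogen-bond donor does not separate the two groups on this read-out. Measured against the two 1,2,3,4-tetrahydroisoquinolin-3-yl compounds, pyrimidin-2-yl gives a number 14 percentage points lower from compound 2 to compound 4 (beyond the scatter) and a number 10 percentage points lower from compound 1 to compound 4 (within the scatter), so it stands clearly apart from only one of them, whereas 1H-benzimidazol-2-yl stood clearly apart from both. No measurement shown here explains these numbers, and the configurational difference between compounds 1 and 2 has no bearing on this change.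

On these data alone, what stays open is whether the higher numbers of compounds 1 and 2 belong to a saturated ring with an amine at this place or to something else in that group, and a piperidin-2-yl or a plain phenyl group on the same chain carbon would speak to that. Also open, as far as these compounds go, is whether a simple pyridin-2-yl group would read like pyrimidin-2-yl, or whether the ring nitrogens of the entering group matter at all.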